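This account rests on a few compounds, and the source may have more. Where it says the series, first, only, none or still open, it means among the compounds named here.

The measured compounds:

compound 1, `Cc1ccc(C)c(Oc2ccc(CC3SC(=O)NC3=O)cc2)c1`: 238 nM
compound 2, `Cc1ccc(Oc2ccc(CC3SC(=O)NC3=O)cc2)c(C)c1`: 121 nM
compound 3, `Cc1ccccc1Oc1ccc(CC2SC(=O)NC2=O)cc1`: 124 nM

All three were tested in a functional assay for agonist activity at Free fatty acid receptor 1 (Homo sapiens), read by FLIPR, in the presence of a further agent that is not named here; a higher number here means that more compound is needed for the effect, a lower number that less compound is needed. Taken as bare numbers, compound 3 gives the second highest of the three values, but the steps of a 1.0-fold higher number from compound 2 to compound 3 (0.01 log units; within the scatter) and a 1.9-fold lower number from compound 1 to compound 3 (0.28 log units; within the scatter) both lie within the usual scatter, so the three compounds cannot be told apart on these data.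

Compound 4, `O=C1NC(=O)C(Cc2ccc(Oc3ccccc3Cl)cc2)S1`, differs from compound 3 in one place: chloro in place of methyl on an aromatic carbon. For the measured compounds named here, no measured step involves a chloro group; the two known steps concern only a methyl being replaced by hydrogen, and each of them stayed within the scatter. The data therefore offer no reason to expect a move beyond the scatter in this assay in either direction, though the exchange itself is untested here.

Compound 4 is expected to give about 120 nM, with a plausible range from 50 nM to 300 nM. The expected step is a 1.0-fold lower number from compound 3 to compound 4 (0.01 log units; within the scatter).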

Compound 4, half-maximal effective concentration: 1190 nM
Compound 4: middle estimate off by 9.9-fold (1.00 log units), on the low side; the whole stated range lies below it.
By their numbers in this assay, from the lowest: compounds 2, 3 and 1 (each within the scatter of the next); then compound 4.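

In this assay, the exchange of methyl for chloro ortho to a large group gives a 9.6-fold higher number from compound 3 to compound 4 (0.98 log units; beyond the scatter) and so moves the number well beyond the scatter. All three earlier compounds keep the methyl at this position, so their steps, which removed a second methyl from the same ring, could not test it. This position therefore responds strongly to a change of a single heavy atom, even though methyl and chloro match in every count computed here, and nothing measured here explains the step.

On these data alone, it remains open how hydrogen, fluoro, bromo or methoxy would fare at this position, and so whether methyl is specially favoured or chloro specially disfavoured. As far as these compounds go, it is also open whether chloro would give a similar step with a second methyl on the ring, as in compound 1 and compound 2.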